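This account rests on a few compounds, and the source may have more. Where it says the series, first, only, none or still open, it means among the compounds named here.

Compound 1 `COc1cccc(/C=C2\CCC/C(=C\c3cc(OC)c(OC)c(OC)c3)C2=O)c1OC` gives 18800 nM in an ADME assay on NHDF cells (Homo sapiens) for cytotoxicity (on this read-out higher numbers stand for weaker inhibition and lower numbers for stronger inhibition), compound 2 `COc1cc(/C=C2\CCC/C(=C\c3ccc(O)c(O)c3)C2=O)cc(OC)c1OC` gives 9000 nM, and compound 3 `COc1cc(/C=C2\CCC/C(=C\c3ccccc3F)C2=O)cc(OC)c1OC` gives 4000 nM. Compound 2 thus holds the second highest of the three numbers: nearest is compound 1, with a 2.1-fold lower number from compound 1 to compound 2 (0.32 log units; beyond the scatter); furthest is compound 3, with a 2.3-fold lower number from compound 2 to compound 3 (0.35 log units; beyond the scatter). Compound 4 `COc1ccc(/C=C2\CCC/C(=C\c3cc(OC)c(OC)c(OC)c3)C2=O)cc1OC` differs from compound 2 by 3,4-dimethoxyphenyl in place of 3,4-dihydroxyphenyl on a double-bonded chain carbon bound to a double-bonded ring carbon. Among the compounds with values here, no measured step swaps these two groups directly. The nearest guide is the step from compound 1 to compound 2, where a dimethoxy-bearing ring gave way to a dihydroxy-bearing one and the number fell modestly, by a 2.1-fold lower number from compound 1 to compound 2 (0.32 log units; beyond the scatter). Reversing that kind of exchange, a modest rise of about a 1.6-fold higher number from compound 2 to compound 4 (0.19 log units; within the scatter) is expected, so compound 4 is estimated at 14000 nM, within 6000 nM to 35000 nM.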

Compound 4, half-maximal inhibitory concentration: 5800 nM
Compound 4: the middle estimate sits 2.4-fold (0.38 log units) above what was measured, and the stated range ends above it.
By their numbers in this assay, from the lowest: compounds 3, 4 and 2 (each within the scatter of the next, the first and the last beyond it); then compound 1.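

In this assay, 3,4-dimethoxyphenyl in place of 3,4-dihydroxyphenyl gives a 1.6-fold lower number from compound 2 to compound 4 (0.19 log units; within the scatter) and in place of 2-fluorophenyl gives a 1.5-fold higher number from compound 3 to compound 4 (0.16 log units; within the scatter), so this position does not separate these three groups. Within the data shown here, the step to 2,3-dimethoxyphenyl is different: a 3.2-fold lower number from compound 1 to compound 4 (0.51 log units; beyond the scatter) shows that, at this place, two dimethoxyphenyl groups can be told apart, which no earlier pair could show. Whether a phenyl ring carrying an amine or a carboxylic acid would fall among these numbers stays open. No measurement here accounts for these steps.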